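Three Cytotoxicity Limits and an Untested Dichloro Analogue

A few compounds are considered here, and "the series" means these few. Any claim that something is new, unique, unknown or untested is made for them only; others in the source may bear on it.

Compound 1 `O=[N+]([O-])c1cc(CSc2nnc(-c3ccccc3)n2Cc2ccccc2)cc([N+](=O)[O-])c1` was tested in an ADME assay on HepG2 cells (Homo sapiens) for cytotoxicity, with a stated time of 48 h; on this read-out higher numbers stand for weaker inhibition and lower numbers for stronger inhibition. In this assay compound 1 gives > 30000 nM, which is a limit of the assay and not a number. Compound 2 `O=[N+]([O-])c1cc(CSc2nnc(-c3ccc(Cl)cc3)n2Cc2ccccc2)cc([N+](=O)[O-])c1` differs from compound 1 by chloro in place of hydrogen on an aromatic carbon. In this assay compound 2 gives > 30000 nM, again only a limit. The step that the two limits leave unreadable from compound 1 to compound 2 is therefore unreadable. Compound 3 `Cn1c(SCc2ccc(Cl)cc2)nnc1-c1cc([N+](=O)[O-])cc([N+](=O)[O-])c1` has another core, and the difference between the two cores is not broken down here. In this assay compound 3 gives > 30000 nM, once more a limit. Compound 4 `Cn1c(SCc2ccc(Cl)c(Cl)c2)nnc1-c1cc([N+](=O)[O-])cc([N+](=O)[O-])c1`, not yet measured, differs from compound 3 by chloro in place of hydrogen on an aromatic carbon. This is the same kind of change as that between compound 1 and compound 2, but here the entering chloro sits ortho to a chloro group and meta to a large group, whereas in compound 2 it sits para to a large group. Because the limit of > 30000 nM in this assay, at which 3 of the 3 values shown sit, shows all measured values resting at the limit, the expected step is a step that the limit leaves unreadable from compound 3 to compound 4. Compound 4 is accordingly estimated at 50000 nM, most likely reported as a limit.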

Compound 4, half-maximal inhibitory concentration: > 30000 nM
Compound 4: only a limit was reported (the forecaster's own chance of this, stated with the estimate: 85%); the middle value lies beyond the limit too.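

No step can be read between compound 3 and compound 4, as both results are only limits: the limit of > 30000 nM in this assay, at which 4 of the 4 values shown sit.

The compounds shown leave open whether any of them reaches a measurable half-maximal value in this assay, and what the added chloro changes there.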